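Benzimidazole in Place of Hydroxyalkyl on the Triazole Nitrogen

The source may report more compounds than this note shows. Statements on the series, on what has been measured and on what is new or still open speak of the compounds shown alone.

Measured compounds:
compound 1, `CN(CCNCc1cn(C(C)(C)C)nn1)CCNc1ccnc2cc(Cl)ccc12`, 56000 nM
compound 2, `CN(CCNCc1cn(CCCO)nn1)CCNc1ccnc2cc(Cl)ccc12`, > 200000 nM

In a functional assay on HCC827 cells (Homo sapiens) for antiproliferative activity, read by sulforhodamine B assay, with a stated time of 72 h (on this read-out lower numbers stand for stronger inhibition and higher numbers for weaker inhibition), compound 1 gives 56000 nM. For compound 2 only a limit of this assay is reported, > 200000 nM. Going by the values given here, compound 2 thus stands at the weak end of what is known, and the single measured step, an at least 3.5-fold higher number from compound 1 to compound 2 (0.55 log units; beyond the scatter), is bounded by the limit of > 200000 nM in this assay, at which 1 of the 2 values shown sits, rather than fixed as a number.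

Compound 3, `CN(CCNCc1cn(Cc2nc3cc(Cl)ccc3[nH]2)nn1)CCNc1ccnc2cc(Cl)ccc12`, differs from compound 2 by 5-chloro-1H-benzimidazol-2-yl in place of 2-hydroxyethyl on a saturated chain carbon bound to an aromatic nitrogen. Among the compounds with values here, no measured step covers a change of this kind; the only step known runs from tert-butyl to 3-hydroxypropyl on the same aromatic nitrogen and weakened activity by at least a modest amount. The expectation for compound 3 therefore rests on two points. For compound 2 only a limit of this assay is known. Compound 1, with tert-butyl in that place, gives 56000 nM. Compound 3 is estimated at 70000 nM, with a range from 15000 nM to 250000 nM. The expected step is an at least 2.8-fold lower number from compound 2 to compound 3 (0.45 log units; beyond the scatter), and the chance that compound 3 also returns only a limit is considerable.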

Compound 3, half-maximal inhibitory concentration: 65000 nM
Beside the measured number, compound 3's estimate is 1.1-fold (0.03 log units) above it, and the stated range covers the measured number.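

The position on the triazole nitrogen is not closed to a large substituent: a (5-chloro-1H-benzimidazol-2-yl)methyl group, carrying two aromatic rings, replaces 3-hydroxypropyl with an at least 3.0-fold lower number from compound 2 to compound 3 (0.48 log units; beyond the scatter). The size of that step is not fixed as a number, since one end of it is a limit of the assay: the limit of > 200000 nM in this assay, at which 1 of the 3 values shown sits. Against tert-butyl on the same aromatic nitrogen, the new group shows a 1.2-fold higher number from compound 1 to compound 3 (0.06 log units; within the scatter), so in this assay two substituents that share little in size or shape read alike, and among the compounds shown only the one with the 3-hydroxypropyl chain falls to the limit.

As far as these compounds go, it remains open whether the chlorine on the benzimidazole contributes anything, as a (1H-benzimidazol-2-yl)methyl group without it or a plain benzyl group could read the same or differently at this place. Also open, from the compounds shown here alone, is whether the weak end is tied to the hydroxyl itself or to the chain, which a propyl chain ending in an amine or a carboxylic acid, or a plain propyl group, would help to separate.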